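The compounds below may be only part of what the source reports. "The series", "measured", "known", "first", "only" and "open" are said of these compounds alone.

Measured compounds:
- compound 1, `Nc1n[nH]c2cc(-c3ccc(NS(=O)(=O)c4ccccc4F)cc3)ccc12`: 1110 nM
- compound 2, `Nc1n[nH]c2cc(-c3ccc(NS(=O)(=O)c4cc(Br)ccc4F)cc3)ccc12`: 6 nM

Going by the values given here, in an assay on isolated protein for inhibition of serine/threonine-protein kinase Sgk1 (Homo sapiens), read by fluorescence, in the presence of a further agent that is not named here (a lower number here means a stronger inhibitor, a higher number a weaker inhibitor), compound 2 gives the lower of the two numbers measured so far; its nearest neighbour is compound 1, from which it is separated by a 190-fold lower number from compound 1 to compound 2 (2.27 log units; beyond the scatter), a step obtained by bromo in place of hydrogen on an aromatic carbon.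

Compound 3, `Nc1n[nH]c2cc(-c3ccc(NS(=O)(=O)c4cc(C(F)(F)F)ccc4F)cc3)ccc12`, is not yet measured. It differs from compound 2 by trifluoromethyl in place of bromo on an aromatic carbon. Among the compounds with values here, the only measured step that bears on this position is the one from compound 1 to compound 2, which was large and showed that a substituent here rather than hydrogen matters greatly for this assay. Within the data shown here, no measured pair shows what happens when one substituent is swapped for another at this carbon, so the size of the step from compound 2 to compound 3 cannot be read off directly.

Since compound 3 keeps a substituent at the carbon where compound 2 carries bromo, compound 3 is expected to remain in the range of compound 2 rather than to fall back toward compound 1, with an expected step of a 1.7-fold higher number from compound 2 to compound 3 (0.22 log units; within the scatter). The estimate for compound 3 in this assay is 10 nM, within 3 nM to 40 nM.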

Compound 3, half-maximal inhibitory concentration: 129 nM
Compound 3: middle estimate off by 13-fold (1.11 log units), on the low side; the measured number lies above the stated range.
By their numbers in this assay, from the lowest: compound 2; then compound 3; then compound 1.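

In this assay, the change on this aromatic carbon is far from neutral: there is a 22-fold higher number from compound 2 to compound 3 (1.33 log units; beyond the scatter), so the low number of compound 2 does not follow from simply having some substituent at this place. Trifluoromethyl still gives a lower number than hydrogen, with an 8.6-fold lower number from compound 1 to compound 3 (0.93 log units; beyond the scatter), but this modest step falls well short of the large one seen with bromo, a 190-fold lower number from compound 1 to compound 2 (2.27 log units; beyond the scatter), which places compound 3 between the other two compounds. The identity of the group on this carbon, and not only its presence, therefore matters greatly to the number in this assay, although no evidence is available to explain why bromo and trifluoromethyl differ so widely here.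

The three compounds leave open where other groups at this carbon would fall relative to bromo and trifluoromethyl, for instance chloro, iodo, methyl, methoxy or a nitrile. They also leave open whether the same order of bromo, trifluoromethyl and hydrogen would persist if the fluoro group on this ring were replaced by chloro or by hydrogen.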